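The source may report more compounds than this note shows. Statements on the series, on what has been measured and on what is new or still open speak of the compounds shown alone.

In a functional assay on RS4-11 cells (Homo sapiens) for inhibition, read by CCK-8 assay, with a stated time of 48 h (on this read-out higher numbers stand for weaker inhibition and lower numbers for stronger inhibition), compound 1 `O=S(=O)(NCCNC(=S)Nc1cccc(Cl)c1)c1ccc(-c2ccccc2OCc2cccc(O)c2)s1` gives 5800 nM and compound 2 `Cc1ccc(-c2ccsc2S(=O)(=O)NCCNC(=O)Nc2cc(C(F)(F)F)cc(C(F)(F)F)c2)c(Oc2ccc(O)c(O)c2)c1` gives 5600 nM. Compound 3 `COc1cccc(NC(=S)NCCNS(=O)(=O)c2ccc(-c3ccccc3Oc3ccc([N+](=O)[O-])cc3)s2)c1` stands at > 50000 nM, which is a limit and not a number.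

Compound 4 `O=[N+]([O-])c1ccc(Oc2ccccc2-c2ccc(S(=O)(=O)NCCNC(=S)Nc3cccc(Cl)c3)s2)cc1` differs from compound 3 in one place: chloro in place of methoxy on an aromatic carbon, with chloro in place of methoxy on an aromatic carbon, so that 3-methoxyphenyl becomes 3-chlorophenyl. Compound 1 carries the same 3-chlorophenyl group and gives 5800 nM, although the rest of its structure is not that of compound 3. A moderate gain in inhibition in this assay is therefore expected. The estimated step of an at least 2.5-fold lower number from compound 3 to compound 4 (0.39 log units; beyond the scatter) is only loosely sized. Compound 4 is estimated at 20000 nM, with an expected range of 6000 nM to 50000 nM.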

Compound 4, half-maximal inhibitory concentration: > 50000 nM
Compound 4 was reported as a limit; the forecaster's own chance of this, stated with the estimate: 30%; at least 2.5-fold (0.39 log units) between middle value and limit.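

The step from chloro to methoxy on the aromatic carbon cannot be read, because compound 3 and compound 4 both sit at the same limit: the limit of > 50000 nM in this assay, at which 2 of the 4 values shown sit.

With 3-chlorophenyl held fixed, 4-nitrophenyl in place of 3-hydroxybenzyl on the oxygen gives an at least 8.6-fold higher number from compound 1 to compound 4 (0.93 log units; beyond the scatter) in this assay, a size bounded by the limit of compound 4. The group on that oxygen therefore decides the read-out here, and 3-chlorophenyl alone does not secure inhibition.

Open, going by these compounds, is whether chloro and methoxy differ when 3-hydroxybenzyl sits on the oxygen. Also open, on these data alone, is whether an amine in place of the nitro group brings the number back under the limit.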